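This account rests on a few compounds, and the source may have more. Where it says the series, first, only, none or still open, it means among the compounds named here.

Within the data shown here, compound 1, `CCCCOC(=O)CNC(=O)[C@H](CSc1ccc([N+](=O)[O-])cc1[N+](=O)[O-])NC(=O)CC[C@H](N)C(=O)OCCCC`, is measured in a toxicity assay on KB cells (Homo sapiens) for cytotoxicity, read by fluorescence, with a stated time of 3 days (on this read-out lower numbers stand for an effect already at smaller amounts and higher numbers for an effect only at larger amounts of compound), at 107 uM, the only number among the three values. Compound 2, `CCCCOC(=O)CNC(=O)[C@H](CSc1ccc([N+](=O)[O-])cc1[N+](=O)[O-])NC(=O)CC[C@H](Nc1ccc([N+](=O)[O-])cc1[N+](=O)[O-])C(=O)OCCCC`, reaches only the limit > 300 uM in this assay. Compound 3, `CCCCOC(=O)CNC(=O)[C@H](CSc1ccc([N+](=O)[O-])cc1[N+](=O)[O-])NC(=O)CC[C@H](NC(C)=O)C(=O)OCCCC`, likewise stops at the limit > 300 uM. Both departures from compound 1 cap the amine nitrogen: an at least 2.8-fold higher number from compound 1 to compound 2 (0.44 log units; beyond the scatter), and an at least 2.8-fold higher number from compound 1 to compound 3 (0.44 log units; beyond the scatter), each running into (the limit of > 300 uM in this assay, at which 2 of the 3 values shown sit). Compound 4, `CCCCOC(=O)CNC(=O)[C@H](CSc1ccc([N+](=O)[O-])cc1[N+](=O)[O-])NC(=O)CC[C@H](NC(=O)CCc1ccccc1)C(=O)OCCCC`, carries phenethylcarbonyl in place of hydrogen on an amine nitrogen. As another cap on the same nitrogen, compound 4 is expected to behave like compounds 2 and 3. The expected step is a 3.3-fold higher number from compound 1 to compound 4 (0.51 log units; beyond the scatter). For compound 4 the estimate in this assay is 350 uM, with a range of 150 uM to 900 uM, quite possibly reported only as a limit.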

Compound 4, concentration for half-maximal effect: > 300 uM
Compound 4 gave a limit, no number (the forecaster's own chance of this, stated with the estimate: 70%); the middle value lies beyond the limit too.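

In this assay, among these compounds, phenethylcarbonyl on the amine nitrogen gives an at least 2.8-fold higher number from compound 1 to compound 4 (0.44 log units; beyond the scatter), so a third and larger cap, now carrying a six-membered aromatic ring, also leaves compound 1 as the only compound with a number. The steps from compound 2 to compound 4 and from compound 3 to compound 4 cannot be read, as both ends of each are limits. All three capped compounds now stop at the same limit: the limit of > 300 uM in this assay, at which 3 of the 4 values shown sit.

Going by these compounds, how far the capped compounds lie past that limit stays open. So does whether a simple methyl on that nitrogen, leaving it an amine, would still give a number in this assay.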